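This account rests on a few compounds, and the source may have more. Where it says the series, first, only, none or still open, it means among the compounds named here.

Measured compounds in an assay on isolated protein for displacement of a labelled ligand from 5-hydroxytryptamine receptor 6 (Homo sapiens), read by radioligand binding; a lower number here means a stronger inhibitor, a higher number a weaker inhibitor:
- compound 1 `Cc1noc(C)c1-c1ccc(S(=O)(=O)Nc2ccc3c(c2)CCN(C)CC3)cc1` gives 10 nM
- compound 2 `CCCCc1ccc(S(=O)(=O)Nc2ccc3c(c2)CN(C)C3)cc1` gives 5.01 nM
- compound 3 `CCCCc1ccc(S(=O)(=O)Nc2ccc3c(c2)CNCC3)cc1` gives 25.1 nM; 25.1 nM (2 entries)

Compound 2 has the lowest number of the two single values; its nearest neighbour is compound 1, whose number is within the scatter of that of compound 2, so no order between the two can be claimed. Compound 3, which carries a different ring system and no methyl on its ring nitrogen, gives a higher number than compound 2, but the two structures differ in more than one place, so that gap cannot be assigned to any single change.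

Compound 4 `CCCCc1ccc(S(=O)(=O)Nc2ccc3c(c2)CNC3)cc1` is not yet measured. Against compound 2 the change is hydrogen in place of methyl on an amine nitrogen in a ring. Going by the values given here, no measured pair isolates this change. The only pointer is the higher number of compound 3, which also lacks the methyl, against compound 2; on that basis a modest loss is expected, beyond the scatter but not large, with the step from compound 2 to compound 4 estimated at a 3.0-fold higher number from compound 2 to compound 4 (0.48 log units; beyond the scatter). Compound 4 is expected to give 15 nM, plausibly between 5 nM and 45 nM.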

Compound 4, inhibition constant: 50.1 nM
Estimate against measurement, compound 4: 3.3-fold (0.52 log units) below; the measured number lies above the stated range.
By their numbers in this assay, from the lowest: compounds 2 and 1 (each within the scatter of the next); then compound 4.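

In this assay, the methyl on the amine nitrogen in the five-membered non-aromatic ring now has a step of its own: with hydrogen in its place, the series shows a 10-fold higher number from compound 2 to compound 4 (1.00 log units; beyond the scatter). Going by these compounds alone, this is the first pair here that differs in one place, and the step lies beyond the scatter, so the gain from this methyl no longer rests on an indirect pointer. No measurement shown here speaks to the reason for this step.

The compounds shown leave open whether an ethyl, a cyclopropyl or an acetyl on this nitrogen would keep the number of compound 2. Going by these compounds, it also remains open whether hydrogen in place of methyl would give a step of similar size on the larger ring of compound 1.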